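Sulfonamide replaced by pyridyl amide on the anilide nitrogen

A few compounds are considered here, and "the series" means these few. Any claim that something is new, unique, unknown or untested is made for them only; others in the source may bear on it.

Two measured compounds share one core. Compound 1 `CNc1nc(NCc2ccc(NS(=O)(=O)c3ccc(F)cc3)cc2)c2ccccc2n1` gives 5300 nM in a functional assay on HCT-116 cells (Homo sapiens) for inhibition, read by luminescence and resazurin assay, with a stated time of 3 days; a lower number here means a stronger inhibitor, a higher number a weaker inhibitor. Compound 2 `CNc1nc(NCc2ccc(NS(=O)(=O)c3ccc(C)cc3)cc2)c2ccccc2n1` gives 5800 nM in this assay. For the measured compounds named here, the only measured step, a 1.1-fold higher number from compound 1 to compound 2 (0.04 log units; within the scatter), is a methyl in place of fluoro on an aromatic carbon, and its size falls within the scatter, so the two numbers cannot be ordered. Compound 2 has the higher of the two numbers, with compound 1 next to it, within the scatter.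

The next compound, compound 3 `CNc1nc(NCc2ccc(NC(=O)c3ccncc3)cc2)c2ccccc2n1`, differs from compound 2 by (pyridin-4-yl)carbonyl in place of (4-methylphenyl)sulfonyl on a nitrogen on an aromatic ring. Going by the values given here, no measured step touches this part of the molecule: the one step seen changes only a substituent on the leaving ring, and gave no movement beyond the scatter. With the sulfonyl swapped for a carbonyl and the phenyl for a pyridyl, there is no basis in the numbers shown for a shift in either direction, so the expected step is a 1.1-fold lower number from compound 2 to compound 3 (0.02 log units; within the scatter), none beyond the scatter. Compound 3 is therefore estimated at 5500 nM in this assay, with a range from 1800 nM to 17000 nM.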

Compound 3, half-maximal inhibitory concentration: > 20000 nM
Compound 3: no number, only a limit (the forecaster's own chance of this, stated with the estimate: 10%); middle value at least 3.6-fold (0.56 log units) from the limit.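

Compound 3 carries a limit and not a number: the limit of > 20000 nM in this assay, at which 1 of the 3 values shown sits. This position on the nitrogen responds in a way the methyl in place of fluoro did not, which gave only a 1.1-fold higher number from compound 1 to compound 2 (0.04 log units; within the scatter): in this assay, (pyridin-4-yl)carbonyl in place of (4-methylphenyl)sulfonyl gives an at least 3.4-fold higher number from compound 2 to compound 3 (0.53 log units; beyond the scatter), and (pyridin-4-yl)carbonyl in place of (4-fluorophenyl)sulfonyl gives an at least 3.7-fold higher number from compound 1 to compound 3 (0.57 log units; beyond the scatter). Both of these steps lie beyond the scatter and run towards a weaker inhibitor, but they are minimum sizes, so the full loss on leaving the sulfonyl series cannot be read from them.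

The change replaces the sulfonyl with a carbonyl and the carbon-only aromatic ring with a pyridine ring in a single step, so the compounds shown cannot assign the loss to either part. A benzoyl group or a (pyridin-4-yl)sulfonyl group on the same nitrogen would separate the two, and a (pyridin-3-yl)carbonyl group would show whether the place of the ring nitrogen matters.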